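The compounds below may be only part of what the source reports. "The series", "measured", "known", "first", "only" and "open" are said of these compounds alone.

Working notes on the series. Compound 1 `CC(C(=O)NCc1ccc(C(F)(F)F)nc1N1CCCC1)c1ccc(NS(C)(=O)=O)c(F)c1` gives 0.6 nM in a functional assay on CHO-K1 cells for antagonist activity at transient receptor potential cation channel subfamily V member 1 (Homo sapiens), read by FLIPR; on this read-out higher numbers stand for weaker inhibition and lower numbers for stronger inhibition; compound 2 `CC(C(=O)NCc1ccc(C(F)(F)F)nc1N1CCCCC1C)c1ccc(NS(C)(=O)=O)c(F)c1` gives 2.9 nM; compound 3 `CC(C(=O)NCc1ccc(C(F)(F)F)nc1N1CCN(C)CC1)c1ccc(NS(C)(=O)=O)c(F)c1` gives 146 nM, the highest of the three numbers, the steps of a 240-fold higher number from compound 1 to compound 3 (2.39 log units; beyond the scatter) and a 50-fold higher number from compound 2 to compound 3 (1.70 log units; beyond the scatter) both lying far beyond the scatter, against the smaller 4.8-fold higher number from compound 1 to compound 2 (0.68 log units; beyond the scatter). Compound 4 `CC(C(=O)NCc1ccc(C(F)(F)F)nc1N1CCN(Cc2ccccc2)CC1)c1ccc(NS(C)(=O)=O)c(F)c1` carries phenyl in place of hydrogen on a saturated chain carbon bound to an amine nitrogen in a ring; the same difference cut one bond further out reads methyl to benzyl. Within the data shown here, none of the measured steps touches this position: all three vary the ring on the aromatic carbon, so no step bears directly on the change. The expectation in this assay is therefore a step of a 1.2-fold lower number from compound 3 to compound 4 (0.09 log units; within the scatter) of no more than modest size, direction uncertain. Compound 4 is expected at 120 nM (range 25 nM to 600 nM).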

Compound 4, inhibition constant: 8.8 nM
Beside the measured number, compound 4's estimate is 14-fold (1.13 log units) above it; the measured number lies below the stated range.
By their numbers in this assay, from the lowest: compound 1; then compound 2; then compound 4; then compound 3.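

Methyl to benzyl on the saturated chain carbon bound to an amine nitrogen in a ring gives a 17-fold lower number from compound 3 to compound 4 (1.22 log units; beyond the scatter) in this assay. Among these compounds, the earlier compounds varied only the ring on the aromatic carbon, so this is the first indication that this position affects the read-out and accepts phenyl with stronger inhibition. No evidence at hand accounts for the change.

From the compounds shown here alone, whether the gain depends on the phenyl ring or on chain size remains open. An ethyl, a phenethyl or a pyridinylmethyl group in this place would help separate the two.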